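The compounds below may be only part of what the source reports. "The series", "measured", "known", "first", "only" and "open" are said of these compounds alone.

In a functional assay on NCI-H520 cells (Homo sapiens) for inhibition, read by MTT assay, with a stated time of 48 h, tested at 10 uM (on this read-out lower numbers stand for less inhibition and higher numbers for more inhibition at the one concentration tested (going by the name of the read-out)), three compounds have been measured:

compound 1 `CCc1ccc(Nc2cc(NC(=O)Nc3cc(OC)cc(OC)c3)ncn2)cc1` gives 23.5%;
compound 2 `COc1cc(NC(=O)Nc2cc(Nc3cc(F)ccc3OC)ncn2)cc(OC)c1` gives 38%;
compound 3 `CCc1cccc(Nc2cc(NC(=O)Nc3cc(OC)cc(OC)c3)ncn2)c1` gives 23%.

Compound 3 has the lowest number of the three, though only its gap to compound 2 is beyond the scatter: a number 15 percentage points lower from compound 2 to compound 3 (beyond the scatter), whereas a number 0.5 percentage points lower from compound 1 to compound 3 (within the scatter). Compound 4 `COc1cc(NC(=O)Nc2cc(Nc3ccc(OC)c(C)c3)ncn2)cc(OC)c1` differs from compound 3 by 4-methoxy-3-methylphenyl in place of 3-ethylphenyl on a nitrogen on an aromatic ring. For the measured compounds named here, the steps that bear on this are the two that bring a methoxy-bearing aryl onto that nitrogen: a number 14.5 percentage points higher from compound 1 to compound 2 (beyond the scatter), and the reverse, a number 15 percentage points lower from compound 2 to compound 3 (beyond the scatter). Moving an ethyl group on the ring did nothing beyond the scatter, a number 0.5 percentage points lower from compound 1 to compound 3 (within the scatter). A modest rise in this assay is therefore expected for compound 4, a number 7 percentage points higher from compound 3 to compound 4 (within the scatter), giving an estimate of 30% with a range from 18% to 44%.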

Compound 4, a percentage reported as inhibition, at one concentration (the size of the read-out at that concentration, not a potency): 13.5%
Estimate against measurement, compound 4: 16.5 percentage points above; the whole stated range lies above it.
By their numbers in this assay, from the lowest: compounds 4, 3 and 1 (each within the scatter of the next); then compound 2.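

In this assay a methoxy on the aryl group at this nitrogen is not enough to hold the higher number: 4-methoxy-3-methylphenyl falls clearly short of 5-fluoro-2-methoxyphenyl (a number 24.5 percentage points lower from compound 2 to compound 4 (beyond the scatter)). It stands level with both ethylphenyl groups (a number 9.5 percentage points lower from compound 3 to compound 4 (within the scatter); a number 10 percentage points lower from compound 1 to compound 4 (within the scatter)), so among these four groups only 5-fluoro-2-methoxyphenyl stands apart. No measured evidence gives a reason for this.

The compounds shown leave open whether the fluoro or the methoxy of that group sets it apart. They also leave open how an aryl group carrying an amine or a carboxylic acid would read at this nitrogen.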